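Swapping a para dimethylamino for tert-butyl on a trimethoxyphenyl core

The source may report more compounds than this note shows. Statements on the series, on what has been measured and on what is new or still open speak of the compounds shown alone.

Measured compounds and their values:
compound 1 `COc1cc(-c2ccnc3cc(-c4c[nH]c5ccccc45)nn23)cc(OC)c1OC` gives 29 nM
compound 2 `COc1cc(-c2ccnc3cc(-c4ccc(N(C)C)cc4)nn23)cc(OC)c1OC` gives 1100 nM
compound 3 `COc1cc(-c2ccnc3cc(-c4cccc5c4ccn5CO)nn23)cc(OC)c1OC` gives 1100 nM

In a functional assay on A549 cells (Homo sapiens) for inhibition, read by CCK-8 assay, with a stated time of 48 h (a higher number here means a weaker inhibitor, a lower number a stronger inhibitor), compound 2 stands level with compound 3 at the digits shown, the two highest numbers of the three, while compound 1 sits far lower: a 38-fold higher number from compound 1 to compound 2 (1.58 log units; beyond the scatter). The new compound 4 `COc1cc(-c2ccnc3cc(-c4ccc(C(C)(C)C)cc4)nn23)cc(OC)c1OC` keeps the shared core and changes only the group on the six-membered aromatic ring of carbon only: tert-butyl in place of dimethylamino on an aromatic carbon. Within the data shown here, no measured step exchanges one group on that ring for another; the single step from compound 1 to compound 2 replaces the whole aromatic group, so it gives no direct guide here. With nothing to point either way, the number for compound 4 is expected to stay close to that of compound 2, a 1.1-fold lower number from compound 2 to compound 4 (0.04 log units; within the scatter), giving an estimate of 1000 nM with a range from 300 nM to 3500 nM.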

Compound 4, half-maximal inhibitory concentration: > 10000 nM
Compound 4 gave a limit, no number; the forecaster's own chance of this, stated with the estimate: 5%; middle value at least 10-fold (1.00 log units) from the limit.
By their numbers in this assay, from the lowest: compound 1; then compounds 2 and 3 (each within the scatter of the next). At a limit, above all of these: compound 4.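

Compound 4 gives a limit of the assay, not a number: the limit of > 10000 nM in this assay, at which 1 of the 4 values shown sits. Among these compounds, on an aromatic carbon para to a large group, tert-butyl in place of dimethylamino gives an at least 9.0-fold higher number from compound 2 to compound 4 (0.95 log units; beyond the scatter), so changing only this group, and not the whole aromatic group, already moves the result beyond the scatter. Replacing 1H-indol-3-yl with 4-(tert-butyl)phenyl gives an at least 340-fold higher number from compound 1 to compound 4 (2.53 log units; beyond the scatter).

The compounds shown leave open how a primary amine, a methoxy group or a carboxylic acid would behave at this place. On these data alone, the exact size of the step to compound 4 also stays unknown.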